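Halogen placement on the aryl group, a third variant expected

The source may hold more compounds than are shown below. What is called first, only, known or untested is meant among the compounds shown, and "the series" means these compounds.

Compound 1 `Nc1scc(CN2CCN(c3cccc(Cl)c3Cl)CC2)c1C(=O)c1ccc(Cl)cc1`: 3.2%
Compound 2 `Nc1scc(CN2CCN(c3ccc(F)cc3Cl)CC2)c1C(=O)c1ccc(Cl)cc1`: -6.2%

Two compounds share a core and differ only in the aryl group on the amine nitrogen in the ring. In a functional assay on CHO cells with adenosine receptor A1 (Homo sapiens) as the target, read by cAMP accumulation and immunoassay, with a stated time of 6 min, tested at 0.1 uM (on this read-out lower numbers stand for a stronger effect and higher numbers for a weaker effect at the one concentration tested), compound 1 gives 3.2%. In this assay, for the measured compounds named here, compound 2 gives -6.2%, the lowest of the two numbers, with compound 1 as its only neighbour; the change a number 9.4 percentage points lower from compound 1 to compound 2 (within the scatter) lies within the scatter, so the two are indistinguishable here.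

Compound 3 `Nc1scc(CN2CCN(c3ccc(Cl)cc3F)CC2)c1C(=O)c1ccc(Cl)cc1` has not been measured. It differs from compound 2 by 4-chloro-2-fluorophenyl in place of 2-chloro-4-fluorophenyl on an amine nitrogen in a ring. Going by the values given here, the one measured step that bears on this, a change of the aryl group on the same ring nitrogen, was a number 9.4 percentage points lower from compound 1 to compound 2 (within the scatter), within the scatter. On that basis no step beyond the scatter is expected, and the step of a number 4.2 percentage points higher from compound 2 to compound 3 (within the scatter) is expected to be small in either direction. Compound 3 is therefore estimated at -2%, within a range from -16% to 12%.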

Compound 3, a percentage reported as activity, at one concentration (the size of the read-out at that concentration, not a potency): -9.4%
Beside the measured number, compound 3's estimate is 7.4 percentage points above it, within the range that was stated.
By their numbers in this assay, from the lowest: compounds 3, 2 and 1 (each within the scatter of the next, the first and the last beyond it).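

Exchanging the two halogens on the aryl group, which leaves the same atoms joined differently, does not separate the two compounds in this assay, with a number 3.2 percentage points lower from compound 2 to compound 3 (within the scatter) as the step. For the compounds shown here, the aryl group on this ring nitrogen does, however, now give a first step beyond the scatter, a number 12.6 percentage points lower from compound 1 to compound 3 (beyond the scatter), so 4-chloro-2-fluorophenyl and 2,3-dichlorophenyl can be told apart here, although compound 2 lies within the scatter of both. No supporting measurement accounts for either step.

On these data alone, what an unsubstituted phenyl or a methoxyphenyl on this ring nitrogen would give remains open. Also open, as far as these compounds go, is whether the step to compound 3 would hold at other concentrations, as a read-out at a single concentration is not a potency.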